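Oral exposure step from compound 2 to compound 3

A few compounds are considered here, and "the series" means these few. Any claim that something is new, unique, unknown or untested is made for them only; others in the source may bear on it.

Measured in an ADME assay on the whole organism (strain FVB) for pharmacokinetics, with Mus musculus as the target, read by LC-MS, at a dose of 30 mg/kg by the oral route; on this read-out lower numbers stand for lower exposure and higher numbers for higher exposure at the dose given:
- compound 1 `c1cc([C@H]2CC[C@]3(CC2)OOC2(O3)C3CC4CC(C3)CC2C4)ccc1OCCOC1CCNCC1`: 9180 ng.h/mL
- compound 2 `c1cc([C@H]2CC[C@]3(CC2)OOC2(O3)C3CC4CC(C3)CC2C4)ccc1OCC1CCNCC1`: 4040 ng.h/mL

Compound 2 has the lower of the two numbers in this assay, and compound 1 stands above it. Among the compounds with values here, the next compound is compound 3 `N[C@H]1CC[C@@H](Oc2ccc([C@H]3CC[C@]4(CC3)OOC3(O4)C4CC5CC(C4)CC3C5)cc2)CC1`, which has no measurement yet. The structural change is 4-aminocyclohexyl in place of (piperidin-4-yl)methyl on an oxygen on an aromatic ring. Compound 3 has the same atoms as compound 2, joined differently.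

Within the data shown here, only one measured step bears on this change, and it does so indirectly: a 2.3-fold lower number from compound 1 to compound 2 (0.36 log units; beyond the scatter). That step is modest but beyond the scatter. Among the measured compounds shown here, it keeps piperidin-4-yl on both sides, and no measured compound carries 4-aminocyclohexyl. On these data alone, the data therefore give no direction for the new change, and a step of similar modest size in either direction remains open. No step beyond the scatter is expected as the central case. The estimated step is a 1.1-fold higher number from compound 2 to compound 3 (0.05 log units; within the scatter). For compound 3 the expected value is 4500 ng.h/mL, with an estimated range from 1700 ng.h/mL to 12000 ng.h/mL.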

Compound 3, area under the concentration-time curve: 13400 ng.h/mL
Beside the measured number, compound 3's estimate is 3.0-fold (0.47 log units) below it; measured number outside the range, above it.
By their numbers in this assay, from the lowest: compound 2; then compounds 1 and 3 (each within the scatter of the next).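

In this assay this position proves sensitive to how the same atoms are joined, not only to which atoms are present: moving from (piperidin-4-yl)methyl to 4-aminocyclohexyl on the oxygen gives a 3.3-fold higher number from compound 2 to compound 3 (0.52 log units; beyond the scatter). Compound 2 now stands apart from both other compounds, whereas the longer 2-((piperidin-4-yl)oxy)ethyl and the 4-aminocyclohexyl group cannot be told apart, with a 1.5-fold higher number from compound 1 to compound 3 (0.16 log units; within the scatter), so a higher number in this small set is reached with either a piperidine or a cyclohexylamine. Nothing available explains why the rearrangement shifts exposure.

The compounds shown leave open whether the step follows from the amine on the carbon ring, from the shorter link to the oxygen, or from the particular arrangement of the two defined stereocentres in compound 3. Also open, on these data alone, is how this assay would respond to a dimethylamino group in place of the amine on the cyclohexyl ring, or to a morpholine or a carboxylic acid at the same position.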